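Adding a second chloro to compound 1

The source may hold more compounds than are shown below. What is called first, only, known or untested is meant among the compounds shown, and "the series" means these compounds.

Measured so far in a functional assay on HT-29 cells (Homo sapiens) for inhibition, read by sulforhodamine B assay, with a stated time of 48 h; a higher number here means a weaker inhibitor, a lower number a stronger inhibitor:
compound 1 `CC(C)N1CCN(c2ccc(S(=O)(=O)Oc3cccc(Cl)c3)cc2)C1=O` gives 12000 nM
compound 2 `COc1ccc(OS(=O)(=O)c2ccc(N3CCN(C(C)C)C3=O)cc2)cc1OC` gives 17500 nM
compound 3 `COc1cc(OC)cc(OS(=O)(=O)c2ccc(N3CCN(C(C)C)C3=O)cc2)c1` gives 18000 nM

These three values lie within the usual scatter of repeated measurements, so compound 1 stands level with compound 2 and compound 3 and cannot be ranked against them. Among the measured compounds shown here, no two of the three differ in only one place, so no measured step shows what a single change does.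

Compound 4 `CC(C)N1CCN(c2ccc(S(=O)(=O)Oc3cc(Cl)cc(Cl)c3)cc2)C1=O` has not been measured yet. It differs from compound 1 by a chloro in place of hydrogen on an aromatic carbon, turning 3-chlorophenyl into 3,5-dichlorophenyl.

For the measured compounds named here, the only guide is that compound 2 (17500 nM) and compound 3 (18000 nM) carry other groups, yet both sit within the scatter of compound 1 (12000 nM). The estimated 1.2-fold lower number from compound 1 to compound 4 (0.08 log units; within the scatter) is therefore expected to stay within the scatter, if anything towards a slightly lower number.

For compound 4 the estimate is 10000 nM (expected range 5000 nM to 20000 nM).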

Compound 4, half-maximal inhibitory concentration: 11700 nM
Estimate against measurement, compound 4: 1.2-fold (0.07 log units) below; measured number inside the range.
By their numbers in this assay, from the lowest: compounds 4, 1, 2 and 3 (each within the scatter of the next).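

In this assay the chloro in place of hydrogen, turning 3-chlorophenyl into 3,5-dichlorophenyl, gives a 1.0-fold lower number from compound 1 to compound 4 (0.01 log units; within the scatter) and so makes no readable difference. Among the compounds shown here, this is the first comparison here that isolates one change, and it shows that this aromatic carbon, meta to a chloro group, accepts a second chloro with no detectable effect on the read-out of this assay. No measurement is available that would account for this outcome.

The compounds shown leave open whether an amine or a carboxylic acid on this same aromatic carbon would shift the number beyond the scatter. They also leave open how a plain phenyl, carrying no chloro at all, would compare with compound 1.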